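Swapping the ring at the chain end of compound 1

This account rests on a few compounds, and the source may have more. Where it says the series, first, only, none or still open, it means among the compounds named here.

Measured in a functional assay on A549 cells (Homo sapiens) for cytotoxicity, read by MTT assay, with a stated time of 48 h; on this read-out lower numbers stand for stronger inhibition and higher numbers for weaker inhibition:
- compound 1 (`COc1cc(/C=C2\C(=O)Nc3ccc(Cl)cc32)ccc1OCCCN1CC(C)OC(C)C1`): 6250 nM
- compound 2 (`COc1cc(/C=C2\C(=O)Nc3ccc(C)cc32)ccc1OCCCN1CC(C)OC(C)C1`): > 20000 nM (a limit)

Going by the values given here, compound 1 (6250 nM) holds the only actual number so far. Compound 2 (> 20000 nM) has a limit of the assay in place of a number. Compound 3 (`COc1cc(/C=C2\C(=O)Nc3ccc(Cl)cc32)ccc1OCCCN1CCN(C)CC1`) alters one group of compound 1 (4-methylpiperazin-1-yl in place of 2,6-dimethylmorpholin-4-yl on a saturated chain carbon, three bonds along the chain from an oxygen on an aromatic ring): 4-methylpiperazin-1-yl in place of 2,6-dimethylmorpholin-4-yl on a saturated chain carbon. Among the compounds with values here, the one measured step (an at least 3.2-fold higher number from compound 1 to compound 2 (0.50 log units; beyond the scatter)) is methyl in place of chloro on an aromatic carbon and leaves that group untouched, so no measured step bears directly on this change. In this assay the expected step is therefore none beyond the scatter, with no settled direction (a 1.0-fold lower number from compound 1 to compound 3 (0.02 log units; within the scatter)). Compound 3 is estimated at 6000 nM (expected range 2200 nM to 18000 nM).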

Compound 3, half-maximal inhibitory concentration: 11300 nM
For compound 3 the middle estimate is 1.9-fold (0.27 log units) below the measured one; measured number inside the range.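

In this assay, going by these compounds alone, the first measured change at this position is a 1.8-fold higher number from compound 1 to compound 3 (0.26 log units; within the scatter) and so does not separate 2,6-dimethylmorpholin-4-yl from 4-methylpiperazin-1-yl. Within the data shown here, the earlier step, on an aromatic carbon, left this position untouched, so this is the only reading of the chain end so far. Nothing shown gives a reason for this result.

Still open, going by these compounds, is whether a piperidine, a dimethylamine or an unsubstituted morpholine at the chain end would give a step beyond the scatter. On these data alone, a longer chain between the oxygen and the ring is equally open.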